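Moving the Ring Nitrogen: From Compound 2 to Compound 4

The compounds below may be only part of what the source reports. "The series", "measured", "known", "first", "only" and "open" are said of these compounds alone.

Measured so far in an ADME assay on BV-2 cells (Mus musculus) for cytotoxicity, with a stated time of 24 h, tested at 50 uM; a higher number here means a weaker effect of the compound at the concentration tested, a lower number a stronger effect:
compound 1, `COc1ccccc1S(=O)(=O)/C=C/c1ccccn1`, gives 100%;
compound 2, `COc1ccccc1S(=O)(=O)/C=C/c1cccnc1`, gives 92%;
compound 3, `COc1ccccc1S(=O)(=O)/C=C/c1cccnc1OC`, gives 81.9%.

Compound 2 holds the second highest of the three numbers in this assay. Its nearest neighbour is compound 1, whose value lies within the scatter of it, so the two cannot be told apart; its furthest is compound 3, which lies beyond the scatter, as the step of a number 10.1 percentage points lower from compound 2 to compound 3 (beyond the scatter) shows.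

Compound 4, `COc1ccccc1S(=O)(=O)/C=C/c1ccncc1`, has not yet been measured. It differs from compound 2 only in the position of the ring nitrogen: pyridin-4-yl in place of pyridin-3-yl on a double-bonded chain carbon bound to a double-bonded chain carbon.

Among the measured compounds shown here, one measured step bears on this change. It is also a shift of the ring nitrogen, on the same place in the molecule: a number 8 percentage points lower from compound 1 to compound 2 (within the scatter). That step stayed within the scatter. The other step, a number 10.1 percentage points lower from compound 2 to compound 3 (beyond the scatter), concerns a methoxy group and is less relevant here. On this basis, compound 4 is expected to show a step of a number 2 percentage points lower from compound 2 to compound 4 (within the scatter) that stays within the scatter, with no clear direction. Compound 4 is therefore estimated at 90%, with a range from 76% to 100%.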

Compound 4, a percentage reported as activity, at one concentration (the size of the read-out at that concentration, not a potency): 78.9%
Beside the measured number, compound 4's estimate is 11.1 percentage points above it, and the stated range covers the measured number.
By their numbers in this assay, from the lowest: compounds 4 and 3 (each within the scatter of the next); then compounds 2 and 1 (each within the scatter of the next).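

In this assay the position of the ring nitrogen turns out to matter after all: a number 13.1 percentage points lower from compound 2 to compound 4 (beyond the scatter) and this lies beyond the scatter, whereas the earlier shift, a number 8 percentage points lower from compound 1 to compound 2 (within the scatter) stayed within it. Going directly from pyridin-2-yl to pyridin-4-yl gives a number 21.1 percentage points lower from compound 1 to compound 4 (beyond the scatter) and so, on this double-bonded chain carbon, two groups with the same heavy atoms and the same counts of hydrogen-bond donors and acceptors can still differ clearly in the size of the effect. Nothing available here explains why this single change in the ring alters the read-out.

The compounds shown leave open whether a methoxy group on the pyridin-4-yl ring would lower the number as it does on the pyridin-3-yl ring, and whether the ring nitrogen is needed at all, which a plain phenyl ring in the same place would test. An amine or a carboxylic acid on the ring could also move the read-out in either direction, and these single-concentration values do not give a potency for any of the compounds.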